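Replacing a Benzyloxy Group with Methoxycarbonyl

The compounds below may be only part of what the source reports. "The series", "measured", "known", "first", "only" and "open" are said of these compounds alone.

This account follows a small set of ureas that share one core and differ only in the substituent on the phenyl ring attached to the cyclopentane. In an assay on microsomes for inhibition of acyl-CoA:cholesterol acyltransferase (Oryctolagus cuniculus) (on this read-out higher numbers stand for weaker inhibition and lower numbers for stronger inhibition), compound 1 `Cc1ccccc1C1(CNC(=O)Nc2c(C(C)C)cccc2C(C)C)CCCC1` gives 17 nM, compound 2 `CC(C)c1cccc(C(C)C)c1NC(=O)NCC1(c2cccc(OCc3ccccc3)c2)CCCC1` gives 30 nM, and compound 3 `CC(C)c1cccc(C(C)C)c1NC(=O)NCC1(c2ccc(OCc3ccccc3)cc2)CCCC1` gives 34 nM. Compound 3 carries the highest of the three numbers, yet its gap to compound 2 and its gap to compound 1 both fall within the usual scatter, so no ordering among the three can be claimed from these values.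

Compound 4 `COC(=O)c1ccc(C2(CNC(=O)Nc3c(C(C)C)cccc3C(C)C)CCCC2)cc1` has not yet been measured. Compared with compound 3 the change is methoxycarbonyl in place of benzyloxy on an aromatic carbon. The benzyloxy group leaves and a methoxycarbonyl enters on an aromatic carbon of a six-membered aromatic ring of carbon only, para to a large group.

For the measured compounds named here, no measured pair shows this kind of exchange, so the expectation rests only on the values already seen. The three measured compounds sit close together, and a loss of inhibition that goes somewhat beyond the scatter is expected for compound 4, which in this assay is estimated at 90 nM, within a range from 25 nM to 350 nM, a step of a 2.6-fold higher number from compound 3 to compound 4 (0.42 log units; beyond the scatter).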

Compound 4, half-maximal inhibitory concentration: 360 nM
Compound 4: middle estimate off by 4.0-fold (0.60 log units), on the low side; the whole stated range lies below it.
By their numbers in this assay, from the lowest: compounds 1, 2 and 3 (each within the scatter of the next); then compound 4.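

In this assay the exchange of benzyloxy for methoxycarbonyl on an aromatic carbon, para to a large group, produces an 11-fold higher number from compound 3 to compound 4 (1.02 log units; beyond the scatter) and thereby moves a compound clear of the close group formed by compounds 1, 2 and 3, whose numbers lie within the scatter of one another. Placing 4-(methoxycarbonyl)phenyl in place of 2-methylphenyl on a saturated ring carbon gives a 21-fold higher number from compound 1 to compound 4 (1.33 log units; beyond the scatter) in the same direction, so the substituent on this phenyl ring does matter to the read-out, which the earlier compounds could not show, and here the entering group without a ring goes with the weaker inhibition. Nothing at hand bears on the reason for this rise.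

The compounds shown leave open whether the loss belongs to the methoxycarbonyl group itself or would follow with any small replacement for benzyloxy at this carbon, such as a methoxy group or a methyl group. They also leave open how a carboxylic acid, a primary amide or a longer ester such as benzyloxycarbonyl would behave at the same place.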